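Replacing cyclohexyl with (oxolan-3-yl)methyl on an aromatic nitrogen

This account rests on a few compounds, and the source may have more. Where it says the series, first, only, none or still open, it means among the compounds named here.

In a toxicity assay on HT-29 cells (Homo sapiens) for cytotoxicity (on this read-out higher numbers stand for lower toxicity in this test and lower numbers for higher toxicity in this test), compound 1 `CN1C(=S)[C@@H](NC(=O)c2nc(Cc3ccccc3)n(CCCF)n2)COc2ccccc21` gives > 100000 nM, which is a limit of the assay and not a number. Compound 2 `CN1C(=S)[C@@H](NC(=O)c2nc(Cc3ccccc3)n(C3CCCCC3)n2)COc2ccccc21` gives > 100000 nM, which is likewise only a limit. Going by the values given here, the single measured step, a step that the two limits leave unreadable from compound 1 to compound 2, therefore has no readable size, and the whole record so far is the limit of > 100000 nM in this assay, at which 2 of the 2 values shown sit.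

Compound 3 `CN1C(=S)[C@@H](NC(=O)c2nc(Cc3ccccc3)n(CC3CCOC3)n2)COc2ccccc21` differs from compound 2 at one place: (oxolan-3-yl)methyl in place of cyclohexyl on an aromatic nitrogen. The benzyl group and the rest of the shared core stay the same.

The expectation rests on compound 2, whose limit of > 100000 nM is the only starting point. No step beyond the scatter is expected in this assay, in either direction, and a further limit is the likeliest report. The estimated step is a number no higher from compound 2 to compound 3 (the limit leaves the size open). For compound 3 the expected value is 100000 nM, with an estimated range from 30000 nM to 100000 nM.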

Compound 3, half-maximal cytotoxic concentration: > 100000 nM
Compound 3: only a limit was reported; the forecaster's own chance of this, stated with the estimate: 85%; the middle value sits exactly at the limit.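

In this assay compound 3 gives > 100000 nM, which is again only a limit, so the steps to compound 3 from compound 1 and from compound 2 cannot be read. The compounds shown leave open what readable value, if any, a group on that aromatic nitrogen would give, and the record stands at a single point: the limit of > 100000 nM in this assay, at which 3 of the 3 values shown sit.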